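Swapping the ring on the ether chain of compound 3

The source may report more compounds than this note shows. Statements on the series, on what has been measured and on what is new or still open speak of the compounds shown alone.

Among the compounds with values here, this series shares one core, and the three measured members differ only in the group hanging from the ether chain and in the chlorine pattern on the pendant phenyl ring. Compound 1 `CCO/C(O)=C1\C(COCCN2CC(=O)NC2=O)=NC(C)=C(C(=O)OC)C1c1cccc(Cl)c1Cl` gives 3.16 nM in a functional assay (aorta) with Rattus norvegicus as the target; on this read-out lower numbers stand for stronger inhibition and higher numbers for weaker inhibition. Compound 2 `CCO/C(O)=C1\C(COCCn2cc(N)n(C)c2=O)=NC(C)=C(C(=O)OC)C1c1ccccc1Cl` gives 25.1 nM in this assay, and compound 3 `CCO/C(O)=C1\C(COCCn2cc(N)nc2O)=NC(C)=C(C(=O)OC)C1c1ccccc1Cl` gives 31.6 nM. Among the three numbers compound 3 stands at the highest, yet its gap to compound 2 is small: a 1.3-fold higher number from compound 2 to compound 3 (0.10 log units; within the scatter). The gap from compound 1 to compound 3 is the only one beyond the scatter, but those two compounds differ in two places at once, so it cannot be pinned to either change alone.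

Compound 4 `CCO/C(O)=C1\C(COCCN2CC(=O)NC2=O)=NC(C)=C(C(=O)OC)C1c1ccccc1Cl` is unmeasured. Its difference from compound 3 is 2,4-dioxoimidazolidin-1-yl in place of 4-amino-2-hydroxy-1H-imidazol-1-yl on a saturated chain carbon, two bonds along the chain from an oxygen on a saturated carbon. Within the data shown here, no measured pair isolates this exchange. Among the measured compounds shown here, the one single-point step available, from compound 2 to compound 3, shows that a change of the same kind at the same place on the chain stayed within the scatter. Compound 1, which carries the entering group on a different phenyl, gives the lowest number seen. On this basis compound 4 is expected to land somewhat lower than compound 3, estimated at 12 nM with a range from 3 nM to 40 nM, a step of a 2.6-fold lower number from compound 3 to compound 4 (0.42 log units; beyond the scatter).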

Compound 4, half-maximal inhibitory concentration: 20 nM
Estimate against measurement, compound 4: 1.7-fold (0.22 log units) below, and the stated range covers the measured number.
By their numbers in this assay, from the lowest: compound 1; then compounds 4, 2 and 3 (each within the scatter of the next).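

Putting 2,4-dioxoimidazolidin-1-yl in place of 4-amino-2-hydroxy-1H-imidazol-1-yl in this assay gives a 1.6-fold lower number from compound 3 to compound 4 (0.20 log units; within the scatter) and the comparison with the methylated aromatic ring gives a 1.3-fold lower number from compound 2 to compound 4 (0.10 log units; within the scatter) so at this place on the chain the non-aromatic ring and the two aromatic rings cannot be told apart by this read-out. Compound 4 also splits the one large gap in the series into its parts: with the chain group held constant, hydrogen in place of chloro on an aromatic carbon gives a 6.3-fold higher number from compound 1 to compound 4 (0.80 log units; beyond the scatter) and so the difference between compound 1 and the rest follows the chlorine on the phenyl ring, not the ring on the chain. Nothing available here accounts for either result.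

As far as these compounds go, the chlorine step rests on this single pair, so whether it would hold with 4-amino-2-hydroxy-1H-imidazol-1-yl on the chain remains open. Also open, from the compounds shown here alone, is how far this tolerance at the chain end extends, for instance to a simple amine, a carboxylic acid or a longer chain in place of the ring.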